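The compounds below may be only part of what the source reports. "The series", "measured", "known", "first", "only" and "open" are said of these compounds alone.

Measured compounds:
Compound 1 `Cc1ccccc1-n1nc(C)c2c1NC(=O)[C@H](C)S[C@@H]2c1ccc(/C=C/c2ccccc2)cc1`, in an assay on isolated protein for agonist activity at Bile acid receptor (Homo sapiens), read by AlphaScreen, with a stated time of 30 min (on this read-out lower numbers stand for an effect already at smaller amounts and higher numbers for an effect only at larger amounts of compound), compound 1 gives "not active" (no number reported).
Compound 2 `Cc1ccccc1-n1nc(C)c2c1NC(=O)[C@H](C)S[C@@H]2c1ccc(-c2ccoc2)cc1`, in this assay compound 2 gives 3500 nM.
Compound 3 `COC(=O)c1ccc(-c2ccc([C@H]3S[C@@H](C)C(=O)Nc4c3c(C)nn4-c3ccccc3C)cc2)cc1`, in this assay compound 3 gives "not active" (no number reported).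

All three share the same core and differ only in the group carried on the outer aromatic ring. Compound 3 stands without a single number in this assay, and compound 1 is in the same position; only compound 2 yields a value there. Compound 4 `COc1cccc(Oc2ccc([C@H]3S[C@@H](C)C(=O)Nc4c3c(C)nn4-c3ccccc3C)cc2)c1` is the next compound to be tested in this assay. It differs from compound 3 in one place: 3-methoxyphenoxy in place of 4-(methoxycarbonyl)phenyl on an aromatic carbon. Among the compounds with values here, since compound 3 has no number, no step between the two can be computed, and no direction of change can be read from the data. Within the data shown here, what can be said is that every compound measured so far sits either without a number or at the weak end of the scale in this assay, so a large move toward small concentrations is not expected. Compound 4 is expected to give about 6000 nM in this assay, with a plausible range from 1500 nM to 30000 nM, and a fair chance that only a limit is reported.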

Compound 4, half-maximal effective concentration: 1700 nM
Estimate against measurement, compound 4: 3.5-fold (0.55 log units) above; the range from low to high includes it.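

In this assay this aromatic carbon can hold a 3-methoxyphenoxy group and still give a number: compound 4 gives 1700 nM here, while compound 3, with 4-(methoxycarbonyl)phenyl in the same place, gives "not active" (no number reported) and so shows that two groups with the same counts of hydrogen-bond donors and acceptors, each holding a six-membered aromatic ring of carbon only, can end differently. Within the data shown here, replacing furan-3-yl with 3-methoxyphenoxy gives a 2.1-fold lower number from compound 2 to compound 4 (0.31 log units; beyond the scatter), a modest step but beyond the usual scatter, and it is the first change at this position whose size can be read, since steps to compound 4 from compound 1 or compound 3 cannot be read without a number. No measurement at hand explains why these groups differ in this way.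

The compounds shown leave open whether the methoxy group of compound 4 contributes at all, which a plain phenoxy group at this position would help to settle. They also leave open how the number would respond to a quite different group on this carbon, such as an amine or a carboxylic acid.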